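This account rests on a few compounds, and the source may have more. Where it says the series, first, only, none or still open, it means among the compounds named here.

Measured in a functional assay on MT4 cells (Homo sapiens) for cytotoxicity; on this read-out lower numbers stand for higher toxicity in this test and higher numbers for lower toxicity in this test:
compound 1 `CC1N=C(S)N(Nc2cccc(Cl)c2)C1C`: 259000 nM
compound 2 `CC1N=C(S)N(Nc2ccccc2)C1C`: 181000 nM
compound 3 `CC1N=CN(Nc2ccccc2)C1C`: 351000 nM

Compound 2 carries the lowest number of the three, yet neither neighbour is separated from it beyond the scatter: a 1.4-fold lower number from compound 1 to compound 2 (0.16 log units; within the scatter); a 1.9-fold higher number from compound 2 to compound 3 (0.29 log units; within the scatter).

Compound 4 `Cc1cccc(NN2C(S)=NC(C)C2C)c1` is the next step from compound 2: methyl in place of hydrogen on an aromatic carbon.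

Among the compounds with values here, the only measured step on the aromatic ring is the one from compound 1 to compound 2, and it stays within the scatter; no methyl step has been measured anywhere. The change to compound 4 is therefore expected to give no step beyond the scatter in this assay, the expected step being a 1.0-fold higher number from compound 2 to compound 4 (0.02 log units; within the scatter).

Compound 4 is estimated at 190000 nM, with a range from 95000 nM to 380000 nM.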

Compound 4, half-maximal cytotoxic concentration: 360000 nM
Compound 4: the middle estimate sits 1.9-fold (0.28 log units) below what was measured; low and high end bracket the measured number.
By their numbers in this assay, from the lowest: compounds 2, 1, 3 and 4 (each within the scatter of the next).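

In this assay methyl in place of hydrogen on an aromatic carbon stays within the scatter (a 2.0-fold higher number from compound 2 to compound 4 (0.30 log units; within the scatter)), and methyl in place of chloro does too (a 1.4-fold higher number from compound 1 to compound 4 (0.14 log units; within the scatter)). At this place on the six-membered aromatic ring, meta to a group of 9 heavy atoms, hydrogen, chloro and methyl now make three groups with no step beyond the scatter among them. No measured evidence bears on this result.

From the compounds shown here alone, whether an amine, a carboxylic acid or a longer chain at this place would give a step beyond the scatter stays open. So does whether methyl gives a comparable step on compound 3, which has hydrogen in place of sulfanyl.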